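A few compounds are considered here, and "the series" means these few. Any claim that something is new, unique, unknown or untested is made for them only; others in the source may bear on it.

Of the compounds shown here, two have been measured in a functional assay on M21 cells (Homo sapiens) for antiproliferative activity, read by sulforhodamine B assay, with a stated time of 48 h (a higher number here means a weaker inhibitor, a lower number a stronger inhibitor), and both share one core, differing only in the group carried on its carbonyl carbon. Compound 1 `CCCC(=O)Nc1ccc(S(=O)(=O)Oc2ccccc2I)cc1` gives 9000 nM. Compound 2 `CCCCCNC(=O)Nc1ccc(S(=O)(=O)Oc2ccccc2I)cc1` gives 5900 nM. Among the measured compounds shown here, the single step between them, a 1.5-fold lower number from compound 1 to compound 2 (0.18 log units; within the scatter), is too small to read as a real change. Compound 2 thus holds the lower of the two numbers, yet its gap to compound 1 sits inside the scatter, so the two cannot be ordered.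

Compound 3 `O=C(NCC1CCCC1)Nc1ccc(S(=O)(=O)Oc2ccccc2I)cc1` has not yet been measured. It differs from compound 2 in that (cyclopentyl in place of butyl on a saturated chain carbon bound to an amide-type nitrogen). For the measured compounds named here, no measured step tests this same place: the one step available, a propyl to a pentylamino group on the carbonyl carbon, is a larger rebuild and still moved the number only within the scatter. There is no ground here for expecting a shift beyond the scatter in either direction, so the expected step of a 1.1-fold lower number from compound 2 to compound 3 (0.03 log units; within the scatter) is small. Compound 3 is therefore estimated at 5500 nM, with a range from 2500 nM to 12000 nM.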

Compound 3, half-maximal inhibitory concentration: 7600 nM
Compound 3: middle estimate off by 1.4-fold (0.14 log units), on the low side; measured number inside the range.
By their numbers in this assay, from the lowest: compounds 2, 3 and 1 (each within the scatter of the next).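

Setting cyclopentyl in place of butyl on a saturated chain carbon bound to an amide-type nitrogen is the first change tested at this place, and in this assay it gives a 1.3-fold higher number from compound 2 to compound 3 (0.11 log units; within the scatter), so the numbers do not separate compound 2 and compound 3 and a ring at the end of this side group shows no measurable difference from the open chain. The comparison with the shorter group on the carbonyl carbon reads the same way, with (cyclopentylmethyl)amino in place of propyl giving a 1.2-fold lower number from compound 1 to compound 3 (0.07 log units; within the scatter), which means that neither of the two larger groups on the carbonyl carbon can be told apart from propyl in this assay. No measurement is at hand that would explain why these numbers stay so close.

As far as these compounds go, the three compounds show only carbon-only side groups, so it stays open whether an amine or a carboxylic acid on this chain would move the number beyond the scatter. A longer chain or a phenyl ring at the same place also remains untested among the compounds shown here.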